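The compounds below may be only part of what the source reports. "The series", "measured", "known", "first", "only" and "open" are said of these compounds alone.

Measured so far in a functional assay on HCT-116 cells (Homo sapiens) for antiproliferative activity, read by MTT assay, with a stated time of 48 h; on this read-out higher numbers stand for weaker inhibition and lower numbers for stronger inhibition:
Compound 1, `N#CC1=C(N)Oc2c(N)cc3nc4ccccc4nc3c2C12C(=O)N(Cc1cnnn1-c1c(F)cccc1F)c1ccccc12`: in this assay compound 1 gives > 50000 nM, which is a limit of the assay and not a number.
Compound 2, `N#CC1=C(N)Oc2c(N)cc3nc4ccccc4nc3c2C12C(=O)N(Cc1cnnn1-c1ccc([N+](=O)[O-])cc1[N+](=O)[O-])c1ccccc12`: in this assay compound 2 gives 23900 nM.

Compound 2 thus holds the only number shown; the one further value is a limit. For the measured compounds named here, the single measured step is an at least 2.0-fold lower number from compound 1 to compound 2 (0.32 log units; beyond the scatter), and its size rests on (the limit of > 50000 nM in this assay, at which 1 of the 2 values shown sits), so only its minimum is known. Compound 3, `COc1cc(-n2nncc2CN2C(=O)C3(C(C#N)=C(N)Oc4c(N)cc5nc6ccccc6nc5c43)c3ccccc32)c(OC)cc1Cl`, differs from compound 2 by 4-chloro-2,5-dimethoxyphenyl in place of 2,4-dinitrophenyl on an aromatic nitrogen. Going by the values given here, only the step from compound 1 to compound 2 bears on this change, and it shows that exchanging the group on the aromatic nitrogen moves the number by a modest amount or more. Among the compounds with values here, no measured compound carries the 4-chloro-2,5-dimethoxyphenyl group, so its direction is open. A step of no more than modest size, in either direction, is expected. Compound 3 is expected to give 30000 nM in this assay, between 8000 nM and 120000 nM, an expected step of a 1.3-fold higher number from compound 2 to compound 3 (0.10 log units; within the scatter).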

Compound 3, half-maximal inhibitory concentration: > 50000 nM
Compound 3: a limit, no number (the forecaster's own chance of this, stated with the estimate: 40%); at least 1.6-fold (0.22 log units) between middle value and limit.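

In this assay, 4-chloro-2,5-dimethoxyphenyl in place of 2,4-dinitrophenyl on the aromatic nitrogen gives an at least 2.0-fold higher number from compound 2 to compound 3 (0.32 log units; beyond the scatter), so only the minimum size of this step is known. For the compounds shown here, with a second replacement of the 2,4-dinitrophenyl group now ending at a limit, compound 2 remains the only one of the three compounds with a number. Compound 1 and compound 3 both carry a limit and not a number, so the step between them cannot be read and their two phenyl groups cannot be ordered: the limit of > 50000 nM in this assay, at which 2 of the 3 values shown sit.

The compounds shown leave open whether the number of compound 2 depends on both nitro groups or on only one of them. As far as these compounds go, how an unsubstituted phenyl, a phenyl with a single nitro group or a phenyl bearing an amine would read on this aromatic nitrogen also remains open.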